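Cytotoxicity notes: methyl on the ring carbon of the carbamate

The compounds below may be only part of what the source reports. "The series", "measured", "known", "first", "only" and "open" are said of these compounds alone.

The series shares one core carrying a trifluoromethoxy-substituted benzyl arm. Compound 1 `CC1(COCc2ccc(OC(F)(F)F)cc2)CCn2cc([N+](=O)[O-])nc2O1` links that arm through an ether, while compound 2 `O=C(NCc1ccc(OC(F)(F)F)cc1)OCC1CCn2cc([N+](=O)[O-])nc2O1` links it through a carbamate. In an ADME assay on MRC5 cells (Homo sapiens) for cytotoxicity, read by resazurin assay, with a stated time of 72 h (on this read-out lower numbers stand for stronger inhibition and higher numbers for weaker inhibition), compound 1 gives >= 40000 nM, which is a limit of the assay and not a number. In this assay compound 2 gives >= 40000 nM, again a limit of the assay rather than a number. Within the data shown here, compound 2 thus stands at the limit, and the one further value shown sits there as well: the limit of >= 40000 nM in this assay, at which 2 of the 2 values shown sit. Among the measured compounds shown here, no step between measured compounds can be read from this.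

Compound 3 `CC1(COC(=O)NCc2ccc(OC(F)(F)F)cc2)CCn2cc([N+](=O)[O-])nc2O1` differs from compound 2 by methyl in place of hydrogen on a saturated ring carbon. Compound 1 carries the same methyl on the same ring carbon and already sits at the limit with >= 40000 nM. No movement beyond the scatter is expected in this assay. Compound 3 is therefore expected at 40000 nM, within a range from 20000 nM to 80000 nM. The expected step is a number no higher from compound 2 to compound 3 (the limit leaves the size open), most likely reported again as a limit.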

Compound 3, half-maximal inhibitory concentration: >= 40000 nM
Compound 3 was reported as a limit; the forecaster's own chance of this, stated with the estimate: 85%; the middle value lies on the limit itself.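

Compound 2 and compound 3 both sit at a limit of the assay, so no step can be read for methyl in place of hydrogen on a saturated ring carbon in this assay: the limit of >= 40000 nM in this assay, at which 3 of the 3 values shown sit.

The compounds shown leave open whether the methyl, or the ether or carbamate link, alters the read-out at all, with no compound shown off the limit.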